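The source may hold more compounds than are shown below. What is called first, only, known or untested is meant among the compounds shown, and "the series" means these compounds.

Compound 1, `Cc1ccc(Oc2ccc(/C=N/NC(=S)Nc3ccccc3)cc2)cc1`, gives 5.39 in a physicochemical assay for lipophilicity, in phosphate buffer, measured as octanol-water partition, with a stated time of 24 h; on this read-out lower numbers stand for lower lipophilicity and higher numbers for higher lipophilicity.
Compound 2, `S=C(N/N=C/c1ccc(Oc2ccc3ccccc3c2)cc1)Nc1ccc(Cl)cc1`, gives 6.96 in this assay.

Compound 2 stands highest of the two numbers, with compound 1 the nearer one, lower by a gap beyond the scatter. Compound 3, `S=C(N/N=C/c1ccc(Oc2ccc3ccccc3c2)cc1)Nc1ccccc1`, is not yet measured in this assay. It differs from compound 2 in one place: hydrogen in place of chloro on an aromatic carbon. Going by the values given here, no step between two measured compounds covers this change, so the expected step of a number 0.71 log units lower from compound 2 to compound 3 (beyond the scatter) is downward, by a moderate amount beyond the scatter. For compound 3 the estimated value in this assay is 6.25, within 5.9 to 6.6.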

Compound 3, partition coefficient: 6.07
Beside the measured number, compound 3's estimate is 0.18 log units above it, and the stated range covers the measured number.
By their numbers in this assay, from the lowest: compound 1; then compound 3; then compound 2.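

Hydrogen in place of chloro on this aromatic carbon, para to a large group, gives a number 0.89 log units lower from compound 2 to compound 3 (beyond the scatter) in this assay. Going by these compounds alone, this is the first step that isolates one place, and it shows that the chloro at this position counts for a modest change, which compounds 1 and 2 alone could not show. Nothing at hand accounts for the step.

On these data alone, whether a methyl, a methoxy or an amine at this position would raise or lower the number remains open. So does whether chloro on the anilino ring of compound 1 would give a step of similar size.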